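The compounds below may be only part of what the source reports. "The series", "measured", "known", "first", "only" and "open" are said of these compounds alone.

Compound 1 `CNCc1ccc2c(c1)nc(Cn1c(=O)n(C(C)C)c3ccccc31)n2CCC(C)C`: 1480 nM
Compound 2 `CC(C)CCn1c(Cn2c(=O)n(C(C)C)c3ccccc32)nc2cc(CO)ccc21`: 31600 nM
Compound 3 `CC(C)CCn1c(Cn2c(=O)n(C(C)C)c3ccccc32)nc2ccc(CO)cc21`: 81600 nM

In an ADME assay on HEp-2 cells (Homo sapiens) for cytotoxicity (on this read-out lower numbers stand for higher toxicity in this test and higher numbers for lower toxicity in this test), compound 1 gives 1480 nM, compound 2 gives 31600 nM, and compound 3 gives 81600 nM. Compound 3 stands highest of the three, its nearest neighbour being compound 2 and its furthest compound 1, with both gaps beyond the usual scatter. Compound 2 and compound 3 are built from the same atoms joined differently; the difference between the two cores is not broken down here. Compound 1 and compound 2 differ in one place, (methylamino in place of hydroxy on a saturated chain carbon bound to an aromatic carbon), and that change made a 21-fold lower number from compound 2 to compound 1 (1.33 log units; beyond the scatter).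

Compound 4 `CNCc1ccc2nc(Cn3c(=O)n(C(C)C)c4ccccc43)n(CCC(C)C)c2c1` has not yet been measured. It differs from compound 3 by the same change at the same place: methylamino in place of hydroxy on a saturated chain carbon bound to an aromatic carbon. A step of similar size is therefore expected here, a 21-fold lower number from compound 3 to compound 4 (1.32 log units; beyond the scatter), because the same change gave a 21-fold lower number from compound 2 to compound 1 (1.33 log units; beyond the scatter), although this rests on a single earlier example and so the range is kept wide. Compound 4 is thus estimated at 3900 nM in this assay, with an expected range from 1300 nM to 12000 nM.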

Compound 4, half-maximal cytotoxic concentration: 4810 nM
Compound 4: middle estimate off by 1.2-fold (0.09 log units), on the low side; low and high end bracket the measured number.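

In this assay, putting methylamino in place of hydroxy again gives a large drop, with a 17-fold lower number from compound 3 to compound 4 (1.23 log units; beyond the scatter). Set beside the earlier case, the change carries over from one core to the other at much the same size: the same change on two cores in this assay, a 21-fold lower number (1.33 log units; beyond the scatter) from compound 2 to compound 1 and a 17-fold lower number (1.23 log units; beyond the scatter) from compound 3 to compound 4, 1.3-fold (0.10 log units) apart, within the scatter of two such steps. For the compounds shown here, this shows that the step held on these two cores, which are built from the same atoms joined differently, but it rests on only two pairs in a single assay, so it neither explains the drop nor shows that the step would hold on a differently built core.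

The compounds shown leave open whether another group on the same saturated chain carbon, such as dimethylamino, a primary amine or a carboxylic acid, would give a step of similar size. They also leave open whether a longer chain in place of the methyl of methylamino, as in ethylamino, would keep the step at this size.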